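The compounds below may be only part of what the source reports. "The series", "measured", "known", "first", "only" and "open" are said of these compounds alone.

Measured compounds:
Compound 1 `CCN(Cc1cccn1C)C(=O)COc1ccc(C)cc1` gives 21300 nM
Compound 2 `Cc1ccc(OCC(=O)N(Cc2cccs2)c2ncccn2)cc1` gives 3700 nM
Compound 3 `CCN(Cc1cc[nH]c1)C(=O)COc1ccc(C)cc1` gives 21800 nM

All three were tested in an assay on HEK293 cells for agonist activity at transient receptor potential cation channel subfamily M member 8 (Homo sapiens), read by fluorescence and calcium flux, with a stated time of 15 min; on this read-out lower numbers stand for an effect already at smaller amounts and higher numbers for an effect only at larger amounts of compound. Compound 2 stands lowest of the three numbers, and its gaps to compound 1 and to compound 3 both lie beyond the scatter, so compound 2 is the most potent of the measured set. For the measured compounds named here, the only measured step between two compounds that differ in one place, a 1.0-fold higher number from compound 1 to compound 3 (0.01 log units; within the scatter), concerns the group on the saturated chain carbon and stays within the scatter; it does not touch the group on the amide-type nitrogen.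

Compound 4 `Cc1ccc(OCC(=O)N(Cc2cccs2)c2cccnc2)cc1` has not yet been measured. It differs from compound 2 by pyridin-3-yl in place of pyrimidin-2-yl on an amide-type nitrogen. Going by the values given here, no measured pair changes this part of the structure, so neither the size nor the direction of the step can be read from the data at hand. In the absence of such a step, the expected change a 1.4-fold higher number from compound 2 to compound 4 (0.13 log units; within the scatter) is taken as small, with a wide range to cover the uncertainty. For compound 4 the estimate in this assay is 5000 nM, expected to fall between 1500 nM and 20000 nM.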

Compound 4, half-maximal effective concentration: 198 nM
Compound 4: middle estimate off by 25-fold (1.40 log units), on the high side; measured number below the stated range.
By their numbers in this assay, from the lowest: compound 4; then compound 2; then compounds 1 and 3 (each within the scatter of the next).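

For the compounds shown here, putting pyridin-3-yl in place of pyrimidin-2-yl on the amide-type nitrogen gives, in this assay, a 19-fold lower number from compound 2 to compound 4 (1.27 log units; beyond the scatter), the first measured sign that the group at this place matters, since the only earlier step concerned a different part of the structure and stayed within the scatter. The change itself looks modest on paper: both groups are six-membered aromatic rings with the same number of heavy atoms, no hydrogen-bond donors and no net charge, and they differ in having 1 hetero atom rather than 2 and 1 hydrogen-bond acceptor rather than 2, yet the step is large. No measurement on these compounds explains this step, so its origin stays unknown.

With only these two rings compared at this place, the step cannot be assigned to the number of ring nitrogens or to the way the ring is attached. A phenyl ring or a pyridin-4-yl group on the same amide-type nitrogen would help separate these possibilities, and would show whether the lower number is specific to pyridin-3-yl.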